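This account rests on a few compounds, and the source may have more. Where it says the series, first, only, none or still open, it means among the compounds named here.

Measured compounds:
compound 1 `CCC(C(=O)N1CCN(c2ccccc2Cl)CC1)N1C(=O)CCC1=O`: 0%
compound 2 `CCC(C(=O)N1CCN(c2ccccc2F)CC1)N1C(=O)CCC1=O`: 0%

In a functional assay on the whole organism (strain Swiss) with Mus musculus as the target, in the maximal electroshock model, with a stated time of 2 h, at a dose of 300 mg/kg by the intraperitoneal route (on this read-out lower numbers stand for a weaker effect and higher numbers for a stronger effect at the one dose given), compound 1 gives 0%. Compound 2 gives 0% in this assay. Within the data shown here, the only step measured, fluoro in place of chloro on an aromatic carbon, shows no change at the digits printed from compound 1 to compound 2 (within the scatter). Compound 2 thus stands level with compound 1 at the digits shown, and neither compound shows any effect in this model at the dose given.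

Compound 3 `CCC(C(=O)N1CCN(c2cccc(C)c2)CC1)N1C(=O)CCC1=O` is not yet measured. It differs from compound 2 by 3-methylphenyl in place of 2-fluorophenyl on an amine nitrogen in a ring. Among the measured compounds shown here, the one measured step bears on this change only loosely, since it also alters the group on the same ring nitrogen, and it was within the scatter. On that basis no step beyond the scatter is expected in this assay from compound 2 to compound 3, so no change at the digits printed from compound 2 to compound 3 (within the scatter) is estimated. Compound 3 is therefore expected to give 0% in this assay, with a range from 0% to 25%.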

Compound 3, a percentage reported as activity, at one dose (the size of the read-out at that dose, not a potency): 0%
For compound 3 middle estimate and measured number coincide at the digits printed; the measured number falls inside the stated range.
By their numbers in this assay, from the lowest: compounds 1, 2 and 3 (each within the scatter of the next).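

In this assay the new compound gives no change at the digits printed from compound 2 to compound 3 (within the scatter) and also no change at the digits printed from compound 1 to compound 3 (within the scatter) when set against the chlorine-bearing compound. The earlier pair only swapped one halogen for another on the phenyl group, whereas 3-methylphenyl brings a carbon-only group to the same amine nitrogen in a ring, and even this different kind of change leaves the reading where it was, at no effect. Since all three compounds read the same at the bottom of the scale, they cannot be ranked, and no measurement at hand offers an explanation for the lack of effect.

Still open, as far as these compounds go, is whether any group on this phenyl ring can produce an effect at all, such as a methoxy, a trifluoromethyl or a carboxylic acid. Also open, from the compounds shown here alone, is whether replacing the phenyl group itself, for instance with a benzyl group, would lift the reading above zero.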